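The source may hold more compounds than are shown below. What is called first, only, known or untested is meant among the compounds shown, and "the series" means these compounds.

Measured in a functional assay on CHO cells with adenosine receptor A1 (Homo sapiens) as the target, read by cAMP accumulation and immunoassay, with a stated time of 6 min, tested at 0.01 uM; a lower number here means a stronger effect, a higher number a weaker effect of the compound at the concentration tested:
compound 1 `Nc1scc(CN2CCN(c3ccc(F)cc3Cl)CC2)c1C(=O)c1ccc(Cl)cc1`: 6.1%
compound 2 `Nc1scc(CN2CCN(c3cc(F)cc(F)c3)CC2)c1C(=O)c1ccc(Cl)cc1`: -13%

Compound 2 stands lowest of the two numbers; its nearest neighbour is compound 1, and the step of a number 19.1 percentage points lower from compound 1 to compound 2 (beyond the scatter) lies beyond the scatter, though both values sit close to zero. Compound 3 `Nc1scc(CN2CCN(c3cccc(F)c3F)CC2)c1C(=O)c1ccc(Cl)cc1` differs from compound 2 in one place: 2,3-difluorophenyl in place of 3,5-difluorophenyl on an amine nitrogen in a ring. Within the data shown here, the only measured step that bears on this change is a number 19.1 percentage points lower from compound 1 to compound 2 (beyond the scatter), where swapping one difluorophenyl-type pattern for another moved the read-out modestly. Since compound 2 already sits near zero and the change to compound 3 is again a rearrangement of two fluorines on the same ring, the expected step of a number 10 percentage points higher from compound 2 to compound 3 (within the scatter) is small, with no confident direction beyond the scatter. Compound 3 is therefore estimated at -3%, with a range from -20% to 14%.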

Compound 3, a percentage reported as activity, at one concentration (the size of the read-out at that concentration, not a potency): -13%
Compound 3: the middle estimate sits 10 percentage points above what was measured; measured number inside the range.
By their numbers in this assay, from the lowest: compounds 2 and 3 (each within the scatter of the next); then compound 1.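

In this assay, moving the two fluorines from the 3,5-difluorophenyl to the 2,3-difluorophenyl pattern on the ring nitrogen gives no change at the digits printed from compound 2 to compound 3 (within the scatter) and so leaves the read-out unmoved, which shows that these two arrangements cannot be told apart here. Replacing 2-chloro-4-fluorophenyl with 2,3-difluorophenyl gives a number 19.1 percentage points lower from compound 1 to compound 3 (beyond the scatter) in this assay, so the gap first seen with the 3,5-difluorophenyl compound now appears with a second difluorophenyl pattern. No supporting evidence is available to explain why the two patterns read alike.

Compound 1 differs from both others in carrying a chlorine as well as in its fluorine pattern, so these compounds cannot show which of the two features goes with the gap. On these data alone, how a methoxy group or a nitrile on this phenyl ring would read also remains open, as does any effect at other concentrations.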